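The source may hold more compounds than are shown below. What is called first, only, known or untested is meant among the compounds shown, and "the series" means these compounds.

Compound 1 `COc1cc2ncnc(Nc3ccc(F)c(Cl)c3)c2cc1OCCCCC(=O)Nc1ccc(S(N)(=O)=O)cc1`: 35600 nM
Compound 2 `COc1cc2ncnc(Nc3cccc(Cl)c3)c2cc1OCCCCC(=O)Nc1ccc(S(N)(=O)=O)cc1`: 33200 nM
Compound 3 `COc1ccc(Nc2ncnc3cc(OC)c(OCCCCC(=O)Nc4ccc(S(N)(=O)=O)cc4)cc23)cc1`: 30200 nM

Of the compounds shown here, three built on the same core have been tested in a functional assay on NCI-H1975 cells (Homo sapiens) for antiproliferative activity, read by MTT assay, with a stated time of 72 h; a lower number here means a stronger inhibitor, a higher number a weaker inhibitor. Compound 1 has the highest of the three numbers, but its separation from the others is slight: a 1.1-fold lower number from compound 1 to compound 2 (0.03 log units; within the scatter) and a 1.2-fold lower number from compound 1 to compound 3 (0.07 log units; within the scatter) both lie within the usual scatter of this assay, so no order among compounds 1, 2 and 3 can be read from these figures. All three sit at weak, micromolar-range inhibition.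

Compound 4 `COc1cc2ncnc(Nc3ccc(C)cc3)c2cc1OCCCCC(=O)Nc1ccc(S(N)(=O)=O)cc1` has not yet been measured. It differs from compound 1 in a single place: 4-methylphenyl in place of 3-chloro-4-fluorophenyl on a nitrogen on an aromatic ring. The measured steps that bear on this are those in which the group on that same nitrogen was exchanged, a 1.2-fold lower number from compound 1 to compound 3 (0.07 log units; within the scatter) and a 1.1-fold lower number from compound 2 to compound 3 (0.04 log units; within the scatter), and the smaller exchange on that group, a 1.1-fold lower number from compound 1 to compound 2 (0.03 log units; within the scatter). Each of these three steps stayed within the scatter, so replacing the group on the nitrogen with yet another ring of carbon alone is not expected to move the number beyond the scatter in either direction. Compound 4 is therefore expected to give 32000 nM, with a range of 17000 nM to 60000 nM. The step this estimate implies, a 1.1-fold lower number from compound 1 to compound 4 (0.05 log units; within the scatter), is expected to remain within the scatter.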

Compound 4, half-maximal inhibitory concentration: 19300 nM
Estimate against measurement, compound 4: 1.7-fold (0.22 log units) above; the measured number falls inside the stated range.
By their numbers in this assay, from the lowest: compounds 4, 3, 2 and 1 (each within the scatter of the next).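

In this assay, the 4-methylphenyl group, whose ring carries no halogen and no oxygen, gives the largest steps yet seen for a change on this nitrogen: (a 1.8-fold lower number from compound 1 to compound 4 (0.27 log units; within the scatter)), (a 1.7-fold lower number from compound 2 to compound 4 (0.24 log units; within the scatter)) and, for the exchange of methoxy for methyl on an aromatic carbon, (a 1.6-fold lower number from compound 3 to compound 4 (0.19 log units; within the scatter)). Even these larger steps stay within the scatter, so the four substituted phenyl groups now tried on this nitrogen, with chloro, fluoro, methoxy or methyl on the ring, give numbers that cannot be told apart in this assay. No measurement shown here accounts for the size of these steps.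

From the compounds shown here alone, what remains open is whether any group on this nitrogen can move the number beyond the scatter, for example a phenyl ring bearing an amine or a carboxylic acid, or a cyclohexyl ring in place of the phenyl. Going by these compounds, it is equally open whether the weak activity of this series depends on other parts of the molecule, such as the chain carrying the amide, which a shorter or longer chain would test.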